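The source may hold more compounds than are shown below. What is called first, only, known or untested is meant among the compounds shown, and "the series" means these compounds.

Working notes on the series sharing the core of compound 1 `COc1cc(OC)c2c(=O)cc(C(=O)Nc3ccc(C4CCCCC4)cc3)[nH]c2c1`, a compound for which a functional assay on SEM cells (Homo sapiens) for antiproliferative activity, with a stated time of 72 h (a lower number here means that less compound is needed, a higher number that more compound is needed for the effect), gives "not determined" (no result reported). Compound 2 `COc1cc(OC)c2c(=O)cc(C(=O)Nc3ccc(N4CCN(C)CC4)cc3)[nH]c2c1` stands at > 19800 nM in this assay, which is a limit of the assay and not a number. Within the data shown here, compound 3 `COc1cc(OC)c2c(=O)cc(C(=O)Nc3cc(C(F)(F)F)ccc3Oc3ccccc3OC)[nH]c2c1`, the only member with a measured number, gives 10800 nM in this assay. Among the three entries one sits at a limit of > 19800 nM in this assay, at which 1 of the 3 values shown sits, and one has no result, so compound 2 stands at the weak end of what is visible, with no measured step to any neighbour.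

Compound 4 `COc1cc(OC)c2c(=O)cc(C(=O)Nc3ccc(Oc4ccc([N+](=O)[O-])cc4)cc3)[nH]c2c1` differs from compound 2 by a single change: 4-nitrophenoxy in place of 4-methylpiperazin-1-yl on an aromatic carbon. Among the measured compounds shown here, no step between measured compounds is known, so the size of this change cannot be read from the series. For the measured compounds named here, the single measured number, that of compound 3 at 10800 nM, also carries an aryl ether on the amide side, and on that basis compound 4 is expected near 8000 nM in this assay, within 2000 nM to 30000 nM. The step from compound 2 to compound 4 that this estimate means, an at least 2.4-fold lower number from compound 2 to compound 4 (0.39 log units; beyond the scatter), is expected to be a gain beyond the scatter, though a further limit remains quite possible.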

Compound 4, half-maximal effective concentration: 480 nM
Beside the measured number, compound 4's estimate is 17-fold (1.22 log units) above it; the whole stated range lies above it.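

The first step read in this series shows that the group on this aromatic carbon, para to a large group, can shift the result strongly in this assay: 4-nitrophenoxy in place of 4-methylpiperazin-1-yl gives an at least 41-fold lower number from compound 2 to compound 4 (1.61 log units; beyond the scatter). The change replaces a six-membered non-aromatic ring with 2 hetero atoms by a six-membered aromatic ring of carbon only, and this single pair cannot divide the gain among the parts of that exchange. The step is a minimum and not an exact size, as one end of it is a limit of the assay for compound 2: the limit of > 19800 nM in this assay, at which 1 of the 4 values shown sits.

On these data alone, whether the gain belongs to the ether oxygen, the aromatic ring or the nitro group stays open. An unsubstituted phenoxy group, or an amine or a carboxylic acid in place of the nitro group, would separate these contributions.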